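The source may hold more compounds than are shown below. What is called first, only, known or untested is meant among the compounds shown, and "the series" means these compounds.

Four compounds built around the same extended chain are compared here. Compound 1 `COc1cc(/C=C/C(=O)/C=C/c2cccc3ccccc23)ccc1OCc1cn(CCOc2cc(=O)oc3ccccc23)nn1` and compound 2 `COc1cc(/C=C/C(=O)/C=C/c2cccc3ccccc23)ccc1OCc1cn(CCCOc2cc(=O)oc3ccccc23)nn1` share a naphthalen-1-yl end, while compound 3 `COc1ccc(/C=C/C(=O)/C=C/c2ccc(OCc3cn(CCOc4cc(=O)oc5ccccc45)nn3)c(OC)c2)cc1OC` and compound 4 `COc1ccc(/C=C/C(=O)/C=C/c2ccc(OCc3cn(CCCOc4cc(=O)oc5ccccc45)nn3)c(OC)c2)cc1OC` carry a 3,4-dimethoxyphenyl end instead. The difference between the cores of compound 1 and compound 2 is not broken down here.

In a functional assay on HCT-116 cells (Homo sapiens) for cytotoxicity, read by sulforhodamine B assay, with a stated time of 48 h (on this read-out higher numbers stand for weaker inhibition and lower numbers for stronger inhibition), compound 1 gives 6540 nM, and compound 2 gives 10400 nM. Compound 3 gives 4710 nM in this assay. The step from compound 1 to compound 3 is 3,4-dimethoxyphenyl in place of naphthalen-1-yl on a double-bonded chain carbon bound to a double-bonded chain carbon; it made a 1.4-fold lower number from compound 1 to compound 3 (0.14 log units; within the scatter). Compound 4 has not yet been measured in this assay. For the measured compounds named here, it differs from compound 2 by 3,4-dimethoxyphenyl in place of naphthalen-1-yl on a double-bonded chain carbon bound to a double-bonded chain carbon, the same change, at the same place, as the one between compound 1 and compound 3.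

Because the step of a 1.4-fold lower number from compound 1 to compound 3 (0.14 log units; within the scatter) stayed within the scatter, the expectation for compound 4 is that the same change made on compound 2 will again move the number only a little, and the estimated step from compound 2 to compound 4 is a 1.4-fold lower number from compound 2 to compound 4 (0.14 log units; within the scatter). On that basis compound 4 is expected to give about 7500 nM in this assay, with a likely range from 3500 nM to 16000 nM. This expectation rests on a single earlier pair, so it carries real uncertainty.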

Compound 4, half-maximal inhibitory concentration: 11000 nM
Compound 4: the middle estimate sits 1.5-fold (0.17 log units) below what was measured, within the range that was stated.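

Made on the second core, the change from naphthalen-1-yl to 3,4-dimethoxyphenyl gave a 1.1-fold higher number from compound 2 to compound 4 (0.02 log units; within the scatter) in this assay, so here too the swap moved the number by no more than ordinary repeat measurements would. Set side by side, the two steps do not differ, and their opposite directions should not be read as a real reversal: the same change on two cores in this assay, a 1.4-fold lower number (0.14 log units; within the scatter) from compound 1 to compound 3 and a 1.1-fold higher number (0.02 log units; within the scatter) from compound 2 to compound 4, 1.5-fold (0.17 log units) apart, within the scatter of two such steps. This shows that, across these two pairs, the change carried over from one core to the other as a step too small to separate from the scatter, but it does not show that the two end groups are equivalent in general, nor does it explain why the number barely moved, and two pairs are too few to establish a rule for the whole series.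

The compounds shown leave open whether a quite different group at the same place, such as an amine or a carboxylic acid in place of the methoxy groups of 3,4-dimethoxyphenyl, would produce a step large enough to read clearly. They also leave open whether the same small step would appear on a core with a longer chain, or in other cell lines.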